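Swapping a chloro for a methyl on the pyridine ring

A few compounds are considered here, and "the series" means these few. Any claim that something is new, unique, unknown or untested is made for them only; others in the source may bear on it.

Of the compounds shown here, three have been measured in a physicochemical assay for lipophilicity; a lower number here means a more polar compound, a higher number a more lipophilic compound. Compound 1 `COc1ccc(CN(CCN(C)C)c2ccccc2)cc1` gives 3.9, compound 2 `COc1ccc(CN(CCN(C)C)c2ccc(N)cc2)cc1` gives 3.13, and compound 3 `COc1ccc(CN(CCN(C)C)c2ccc(Cl)cn2)cc1` gives 3.87. Compound 3 thus stands second highest of the three: its value and that of compound 1 lie within the usual scatter of each other, as the step of a number 0.03 log units lower from compound 1 to compound 3 (within the scatter) shows, while compound 2 sits clearly lower, as the step of a number 0.74 log units higher from compound 2 to compound 3 (beyond the scatter) shows. The only step beyond the scatter among these compounds, a number 0.77 log units lower from compound 1 to compound 2 (beyond the scatter), comes from placing an amino group on the aromatic ring.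

Compound 4 `COc1ccc(CN(CCN(C)C)c2ccc(C)cn2)cc1` differs from compound 3 in one place: methyl in place of chloro on an aromatic carbon. Within the data shown here, no measured step involves a methyl in place of a chloro, so nothing among the three compounds speaks directly to this change. Both groups are single heavy atoms without donors, acceptors or charge, so the expected step in this assay is small. The estimated step of a number 0.17 log units lower from compound 3 to compound 4 (within the scatter) is expected to stay within the usual scatter, if anything slightly lower. Compound 4 is therefore expected to give about 3.7, with a likely range from 3.3 to 4.1.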

Compound 4, partition coefficient: 3.79
Beside the measured number, compound 4's estimate is 0.09 log units below it; the measured number falls inside the stated range.
By their numbers in this assay, from the lowest: compound 2; then compounds 4, 3 and 1 (each within the scatter of the next).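

In this assay, methyl in place of chloro on this aromatic carbon, two atoms from the ring nitrogen, gives a number 0.08 log units lower from compound 3 to compound 4 (within the scatter), so this measurement does not separate the two groups at this position. The comparison with the phenyl compound gives the same picture for the new group: 5-methylpyridin-2-yl in place of phenyl gives a number 0.11 log units lower from compound 1 to compound 4 (within the scatter), just as the step to 5-chloropyridin-2-yl stayed within the scatter, while 5-methylpyridin-2-yl in place of 4-aminophenyl gives a number 0.66 log units higher from compound 2 to compound 4 (beyond the scatter), which leaves compound 2 apart from the other three. Chloro and methyl each count one heavy atom with no hydrogen-bond donors or acceptors and no net charge, so the result speaks only to an exchange of that kind.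

As far as these compounds go, whether a carboxylic acid or a longer alkyl chain at this same position would also stay within the scatter of compound 3 remains open. Nothing available explains why this exchange leaves the number within the scatter.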